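Removing the fluoro group from compound 1

The source may report more compounds than this note shows. Statements on the series, on what has been measured and on what is new or still open speak of the compounds shown alone.

Values measured in a functional assay on the whole organism for antagonist activity, with Mus musculus as the target (on this read-out lower numbers stand for an effect already at smaller amounts and higher numbers for an effect only at larger amounts of compound), follow
- Compound 1 `Cn1c(-c2cccc(F)c2)nnc1S(C)(=O)=O` gives 12.1 mg/kg
- Compound 2 `CSc1nnc(-c2ccc(F)cc2)n1C` gives 33.4 mg/kg
- Compound 3 `Cn1c(-c2cccs2)nnc1S(C)(=O)=O` gives > 200 mg/kg

Compound 1 at 12.1 mg/kg has the lowest of the two actual numbers, and compound 2 at 33.4 mg/kg stands higher, beyond the usual scatter. The value of compound 3 at > 200 mg/kg is a limit of the assay and not a number.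

Compound 4 `Cn1c(-c2ccccc2)nnc1S(C)(=O)=O` differs from compound 1 in one place, and the change is hydrogen in place of fluoro on an aromatic carbon with hydrogen in place of fluoro on an aromatic carbon, meta to a large group. Among the measured compounds shown here, no measured pair isolates this change, so in this assay no step beyond the scatter is expected. The estimated 1.3-fold higher number from compound 1 to compound 4 (0.12 log units; within the scatter) stays within that scatter. Compound 4 is therefore expected at 16 mg/kg with a range of 5 mg/kg to 50 mg/kg in this estimate.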

Compound 4, dose for half-maximal effect: 12.8 mg/kg
For compound 4 the middle estimate is 1.3-fold (0.10 log units) above the measured one, and the stated range covers the measured number.
By their numbers in this assay, from the lowest: compounds 1 and 4 (each within the scatter of the next); then compound 2. At a limit, above all of these: compound 3.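

Putting hydrogen in place of fluoro on this aromatic carbon, meta to a large group, gives a 1.1-fold higher number from compound 1 to compound 4 (0.02 log units; within the scatter) in this assay. Among the compounds shown here, at this place, then, the read-out does not depend on the fluoro group, something the earlier compounds could not show, since none of them formed a pair differing only here. Nothing shown here gives a reason for this result. As far as these compounds go, whether a methoxy group, an amine or a carboxylic acid at this place would leave the number within the scatter remains open.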